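The source may report more compounds than this note shows. Statements on the series, on what has been measured and on what is new or still open speak of the compounds shown alone.

Of the compounds shown here, two have been measured so far. In a physicochemical assay for lipophilicity, measured as octanol-water partition, at pH 7.4 (a higher number here means a more lipophilic compound, a lower number a more polar compound), compound 1 `Cc1ccc2[nH]c(C(=O)N[C@@H]3CCN(S(=O)(=O)c4ccccc4)C[C@H]3C(=O)NCCN(C)C)cc2c1` gives 2.3 and compound 2 `Cc1ccc2[nH]c(C(=O)N[C@H]3CN(S(=O)(=O)c4ccccc4)C[C@@H]3C(=O)NC[C@@H]3CCCN3C)cc2c1` gives 2.3, so compound 2 stands level with compound 1 within the scatter of repeated measurements. Compound 3 `Cc1ccc2[nH]c(C(=O)N[C@H]3CN(S(=O)(=O)c4ccccc4)C[C@@H]3C(=O)N[C@H]3CCCN(C)C3)cc2c1` is built from the same atoms as compound 2, joined differently. It carries 1-methylpiperidin-3-yl in place of (1-methylpyrrolidin-2-yl)methyl on an amide-type nitrogen. A five-membered non-aromatic ring thus gives way to a six-membered one, and the rest of the molecule stays the same. Going by the values given here, no measured pair shows this change directly, so the starting point is compound 2 at 2.3. No shift beyond the scatter is expected in this assay, in either direction. The expected step is no change at the digits printed from compound 2 to compound 3 (within the scatter). For compound 3 the estimated value is 2.3, with a likely range of 1.9 to 2.7.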

Compound 3, distribution coefficient: 2.7
Beside the measured number, compound 3's estimate is 0.40 log units below it, within the range that was stated.
By their numbers in this assay, from the lowest: compounds 1 and 2 (each within the scatter of the next); then compound 3.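

In this assay, replacing (1-methylpyrrolidin-2-yl)methyl with 1-methylpiperidin-3-yl on the amide-type nitrogen gives a number 0.40 log units higher from compound 2 to compound 3 (beyond the scatter), so the number at this position can move even when the atoms stay the same. The two groups have matching counts of heavy atoms, hydrogen-bond donors and acceptors, and neither carries a net charge, so these counts do not separate them; they differ in ring size and in how the ring is joined to the nitrogen. No measurement at hand explains this step.

Going by these compounds, compound 2 and compound 3 differ in ring size and attachment together, so the contribution of each remains open. The 1-methylpyrrolidin-3-yl group, a five-membered ring joined directly to the nitrogen, and the (1-methylpiperidin-2-yl)methyl group, a six-membered ring joined through a carbon, could help to separate the two.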